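The source may report more compounds than this note shows. Statements on the series, on what has been measured and on what is new or still open speak of the compounds shown alone.

Working notes on the series.

Compound 2 `COc1cc2c(Oc3ccc(C4SCC(=O)N4NC(=O)Nc4ccc(F)cc4F)cc3F)ccnc2cc1OCCCN1CCN(C)CC1` gives 110 nM in a functional assay on HT-29 cells (Homo sapiens) for cytotoxicity, read by MTT assay, with a stated time of 72 h (a lower number here means a stronger inhibitor, a higher number a weaker inhibitor), the lowest of the two numbers measured. Within the data shown here, compound 1 `CCN1CCN(CCCOc2cc3nccc(Oc4ccc(C5SCC(=O)N5NC(=O)Nc5ccc(F)cc5F)cc4F)c3cc2OC)CC1` is the only comparator, and in this assay compound 1 gives 320 nM; the step of a 2.9-fold lower number from compound 1 to compound 2 (0.46 log units; beyond the scatter) is the one change recorded so far at the terminal amine ring, a change on a saturated chain carbon bound to an amine nitrogen in a ring.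

Compound 3 `COc1cc2c(Oc3ccc(C4SCC(=O)N4NC(=O)Nc4ccc(F)cc4F)cc3F)ccnc2cc1OCCCN1CCCN(C)CC1` carries 4-methyl-1,4-diazepan-1-yl in place of 4-methylpiperazin-1-yl on a saturated chain carbon, three bonds along the chain from an oxygen on an aromatic ring. This touches the same terminal amine ring as the step from compound 1 to compound 2, but alters the ring itself rather than the chain on its nitrogen, so that step only shows that this region tolerates modest alteration with a modest effect. Among the measured compounds shown here, no measured step covers a ring enlargement here, and a step within the scatter, in either direction, is the expectation for compound 3.

Compound 3 is therefore estimated at 150 nM in this assay, within 50 nM to 450 nM, the expected step being a 1.4-fold higher number from compound 2 to compound 3 (0.13 log units; within the scatter).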

Compound 3, half-maximal inhibitory concentration: 180 nM
Compound 3: middle estimate off by 1.2-fold (0.08 log units), on the low side; the measured number falls inside the stated range.
By their numbers in this assay, from the lowest: compounds 2, 3 and 1 (each within the scatter of the next, the first and the last beyond it).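

The seven-membered ring of 4-methyl-1,4-diazepan-1-yl takes the place of the six-membered ring of 4-methylpiperazin-1-yl on the saturated chain carbon in this assay, with a 1.6-fold higher number from compound 2 to compound 3 (0.21 log units; within the scatter), so this position now has a measured change to the ring itself and not only to the group on its nitrogen. Against the 4-ethylpiperazin-1-yl group, the same ring gives a 1.8-fold lower number from compound 1 to compound 3 (0.25 log units; within the scatter), so compound 3 is not separated from either comparator, whereas the two piperazines are separated by a 2.9-fold lower number from compound 1 to compound 2 (0.46 log units; beyond the scatter), a step beyond the scatter. Among these compounds, no measurement on these compounds offers any account of this outcome.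

Still open, as far as these compounds go, is whether the difference between ethyl and methyl on the ring nitrogen carries over to the seven-membered ring, as a 4-ethyl-1,4-diazepan-1-yl group would show. The compounds shown also leave open whether this position depends on a second ring nitrogen at all, which a morpholine or piperidine would address, and whether a shorter chain than the propyl linker holds up in this assay as these three compounds do.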